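This account rests on a few compounds, and the source may have more. Where it says the series, first, only, none or still open, it means among the compounds named here.

Measured compounds:

compound 1 `O=c1[nH]c2ccccc2cc1/C=N/O`: 2010000 nM
compound 2 `O=c1[nH]c2ccccc2cc1/C=N/c1ccc(O)cc1`: "not active" (no number reported) (no number reported)
compound 3 `Cc1ccc2[nH]c(=O)c(/C=N/O)cc2c1`: 1980000 nM

All three were tested in a functional assay, read by spectrophotometry, with a stated time of 1 h; on this read-out higher numbers stand for weaker inhibition and lower numbers for stronger inhibition. Among the numbers shown, compound 1 gives the higher of the two reported values, but compound 3 lies within the scatter of it: the step of a 1.0-fold lower number from compound 1 to compound 3 (0.01 log units; within the scatter) comes from methyl in place of hydrogen on an aromatic carbon and changes nothing of note. Compound 2 gives "not active" (no number reported) and therefore supplies no number at all.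

Compound 4 `CCCC/N=C/c1cc2ccccc2[nH]c1=O` has not yet been measured. It differs from compound 1 in one place: butyl in place of hydroxy on a double-bonded nitrogen. Within the data shown here, no measured step touches this double-bonded nitrogen; the single step already described concerns an aromatic carbon, so it gives no direct guide. What remains is that the two reported numbers both sit in the very weak range, and that compound 2, the other departure from compound 1, gave no number. The expectation is therefore a number for compound 4 no lower than that of compound 1 and quite possibly none at all, with an estimated step of a 2.0-fold higher number from compound 1 to compound 4 (0.30 log units; within the scatter). The estimate for compound 4 in this assay is 4000000 nM, in a range from 1500000 nM to 20000000 nM.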

Compound 4, half-maximal inhibitory concentration: 7680000 nM
Beside the measured number, compound 4's estimate is 1.9-fold (0.28 log units) below it, and the stated range covers the measured number.
By their numbers in this assay, from the lowest: compounds 3 and 1 (each within the scatter of the next); then compound 4.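

In this assay, butyl in place of hydroxy on a double-bonded nitrogen gives a 3.8-fold higher number from compound 1 to compound 4 (0.58 log units; beyond the scatter), which points to weaker inhibition and is modest in size, whereas methyl in place of hydrogen on an aromatic carbon gave only a 1.0-fold lower number from compound 1 to compound 3 (0.01 log units; within the scatter), within the scatter. This double-bonded nitrogen is therefore the one place among the readable steps where a change moves the number beyond the scatter, and compound 4 still gives a number, unlike compound 2. The swap adds heavy atoms and removes the hydrogen-bond donor and acceptor of hydroxy in a single step, and no measurement here separates these changes or explains the shift.

The compounds shown leave open whether the number climbs steadily with chain length at this nitrogen, which a shorter chain such as ethyl or a longer one such as hexyl could test. They also leave open how a chain ending in an amine or a carboxylic acid would read here, and whether the step from hydroxy to butyl would be the same on the methyl-bearing core of compound 3.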